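Changing the aryl on the ring nitrogen: a tolerability outlook

The compounds below may be only part of what the source reports. "The series", "measured", "known", "first", "only" and "open" are said of these compounds alone.

Compound 1 `Cc1ccccc1-c1nn(-c2cc(F)ccc2F)cc1CNCCN1CCN(C)CC1` reaches only the assay limit of > 20000 nM in an ADME assay on Huh-7 cells (Homo sapiens) for cytotoxicity (a lower number here means that less compound is tolerated, a higher number that more compound is tolerated), a limit rather than a number.
Compound 2 `COC(=O)c1ccc(-c2nn(-c3ccc(F)cc3F)cc2CNCCN2CCN(C)CC2)cc1` likewise reaches only a limit, > 20000 nM, in this assay.
Compound 3 `CCCN1CCC(CNCc2cn(-c3ccc(C(F)(F)F)cc3)nc2-c2ccc(Cl)cc2)CC1` gives 1900 nM in this assay.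

Compound 1 thus stands at the ceiling of what this assay reports, as does compound 2, while compound 3 alone returns a number; what unites them is the limit of > 20000 nM in this assay, at which 2 of the 3 values shown sit. Compound 4 `Cc1ccccc1-c1nn(-c2ccc(OC(F)(F)F)cc2)cc1CNCCN1CCN(C)CC1` differs from compound 1 in 4-(trifluoromethoxy)phenyl in place of 2,5-difluorophenyl on an aromatic nitrogen. Among the compounds with values here, no pair of measured compounds isolates this change, so the expectation rests on compound 1 alone. Because compound 1 sits at > 20000 nM, compound 4 is expected to stay close to that limit, with an expected step of an at least 1.3-fold lower number from compound 1 to compound 4 (0.12 log units; that floor lies within the scatter). Compound 4 is estimated at 15000 nM, within 5000 nM to 40000 nM.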

Compound 4, half-maximal cytotoxic concentration: 17000 nM
Compound 4: the middle estimate sits 1.1-fold (0.05 log units) below what was measured; low and high end bracket the measured number.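

Replacing 2,5-difluorophenyl with 4-(trifluoromethoxy)phenyl on the aromatic nitrogen gives, in this assay, an at least 1.1-fold lower number from compound 1 to compound 4 (0.07 log units; that floor lies within the scatter), the first step read at this position. This step is only a floor, and the true size of the change stays unknown, because compound 1 holds a limit rather than a number: the limit of > 20000 nM in this assay, at which 2 of the 4 values shown sit.

The compounds shown leave open how far other groups on this nitrogen would move the read-out in this assay. As far as these compounds go, a carboxylic acid or a morpholine on this aryl ring, for instance, remains untested here.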